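Swapping a Fluorophenyl for Thiophene on a Shared Hydroxamic Acid Core

The source may hold more compounds than are shown below. What is called first, only, known or untested is meant among the compounds shown, and "the series" means these compounds.

Two compounds built on a shared core with a hydroxamic acid have been tested in an assay on Sf9 cells for inhibition of protein deacetylase HDAC6 (Homo sapiens), read by fluorescence, with a stated time of 40 min, tested at 100 nM; on this read-out higher numbers stand for more inhibition at the one concentration tested (going by the name of the read-out) and lower numbers for less inhibition. Compound 1 `COc1ccc(-n2nc(-c3ccc(O)cc3)nc2CNc2ccc(C(=O)NO)cc2)cc1` gives 70.3%, and compound 2 `O=C(NO)c1ccc(NCc2nc(-c3ccc(F)cc3)nn2-c2ccccc2)cc1` gives 70.9%. Compound 2 holds the higher of the two numbers, yet its gap to compound 1 lies within the scatter, so the two cannot be told apart. Compound 3 `O=C(NO)c1ccc(NCc2nc(-c3ccsc3)nn2-c2ccccc2)cc1` has not yet been measured; it differs from compound 2 in one place: thiophen-3-yl in place of 4-fluorophenyl on an aromatic carbon. Among the measured compounds shown here, no measured pair shows what such a change does, so no step can be read from the data. Because compound 1 and compound 2 sit so close at 70.9% despite differing elsewhere, a change at this position is expected to move the number only a little, most likely within the scatter or slightly downward. The step expected is a number 4.9 percentage points lower from compound 2 to compound 3 (within the scatter). Compound 3 is therefore estimated at 66%, with a range from 50% to 82%.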

Compound 3, a percentage reported as inhibition, at one concentration (the size of the read-out at that concentration, not a potency): 53.4%
For compound 3 the middle estimate is 12.6 percentage points above the measured one; low and high end bracket the measured number.
By their numbers in this assay, from the lowest: compound 3; then compounds 1 and 2 (each within the scatter of the next).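

The position on the aromatic carbon of the five-membered aromatic ring with 3 nitrogen now has its first measured step. In this assay, among the compounds shown here, thiophen-3-yl in place of 4-fluorophenyl gives a number 17.5 percentage points lower from compound 2 to compound 3 (beyond the scatter) and so shows that the group at this position can change the read-out, which the earlier compounds could not show. The swap changes several things at once, a six-membered aromatic ring of carbon only with 7 heavy atoms giving way to a five-membered aromatic ring with 1 hetero atom and 5 heavy atoms, and nothing available explains the drop.

The compounds shown leave open whether ring size, the loss of fluorine or the arrival of sulfur matters most. They also leave open how an unsubstituted phenyl, a pyridin-3-yl group or an amine would read at this position.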